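Indolyl azobenzamide series: amide aryl swap

The source may hold more compounds than are shown below. What is called first, only, known or untested is meant among the compounds shown, and "the series" means these compounds.

Compound 1 `Cc1ccc(C)c(NC(=O)c2ccc(/N=N\c3c[nH]c4ccccc34)cc2)c1` was returned as "not active" (no number reported) in a functional assay on P388 cells (Mus musculus) for inhibition, read by MTT assay, with a stated time of 72 h (on this read-out higher numbers stand for weaker inhibition and lower numbers for stronger inhibition), with no number given. For the measured compounds named here, compound 2 `O=C(Nc1ccccc1F)c1ccc(/N=N\c2c[nH]c3ccccc23)cc1` gives 106000 nM in this assay, the only number so far in the set; inhibition is weak. Compound 3 `O=C(Nc1ccc(Cl)cc1)c1ccc(/N=N\c2c[nH]c3ccccc23)cc1` differs by 4-chlorophenyl in place of 2-fluorophenyl on an amide-type nitrogen. Going by the values given here, no measured step is available for this change, so the expected step from compound 2 to compound 3 is estimated as small, a 1.3-fold lower number from compound 2 to compound 3 (0.12 log units; within the scatter), with no direction confidently beyond the scatter. Compound 3 is therefore expected to give about 80000 nM in this assay, with a plausible range from 20000 nM to 300000 nM.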

Compound 3, half-maximal inhibitory concentration: 80000 nM
Beside the measured number, compound 3's estimate shows no gap at the digits printed, and the stated range covers the measured number.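

With the amide-type nitrogen carrying 4-chlorophenyl in place of 2-fluorophenyl, this assay gives a 1.3-fold lower number from compound 2 to compound 3 (0.12 log units; within the scatter), the first step readable in this series, so this aryl swap does not move the read-out beyond the scatter. Compound 1 has no number, so steps to it cannot be read. No measurement available here bears on this result.
Still open, going by these compounds, is whether a carboxylic acid or a dimethylamino group on this aryl ring, or a cyclohexyl group in its place, would shift the number beyond the scatter.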